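Cytotoxicity series: ethyl ester step toward compound 4

This account rests on a few compounds, and the source may have more. Where it says the series, first, only, none or still open, it means among the compounds named here.

Measured in a functional assay on EA.hy 926 cells (Homo sapiens) for cytotoxicity, read by MTT assay, with stated times of 24 h and 12 h, tested at 12.5 uM; a lower number here means a weaker effect, a higher number a stronger effect of the compound at the concentration tested:
compound 1, `COc1cc(/C=C/C(=O)O)ccc1OC(=O)c1nc(C)c(C)nc1C`: 38.7%
compound 2, `Cc1nc(C)c(C(=O)Oc2cccc(/C=C/C(=O)O)c2)nc1C`: 61.6%
compound 3, `CCOC(=O)/C=C/c1ccc(OC(=O)c2nc(C)c(C)nc2C)c(OC)c1`: 52.4%

Compound 1 and compound 3 share a core and differ in one place, (ethyl in place of hydrogen on an oxygen next to a carbonyl group). The step this change made in this assay is a number 13.7 percentage points higher from compound 1 to compound 3 (beyond the scatter), a modest rise and beyond the scatter. The difference between the core of compound 1 and the core of compound 2 is not broken down here. Compound 2 gives a higher number than compound 1, and the values of compound 2 and compound 3 lie within the scatter of each other, so no order between those two is read.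

Compound 4, `CCOC(=O)/C=C/c1cccc(OC(=O)c2nc(C)c(C)nc2C)c1`, has not yet been measured. It stands to compound 2 as compound 3 stands to compound 1: ethyl in place of hydrogen on an oxygen next to a carbonyl group. The place of the change is the same in both pairs, so this is the same change made once more, on the core of compound 2. In this assay, among the measured compounds shown here, the step from compound 2 to compound 4 is expected to be a number 8.4 percentage points higher from compound 2 to compound 4 (within the scatter), set beside a number 13.7 percentage points higher from compound 1 to compound 3 (beyond the scatter) and resting on that single earlier step, because the step of a number 13.7 percentage points higher from compound 1 to compound 3 (beyond the scatter) is the only measured instance of this change. For the measured compounds named here, with only one prior step and a higher starting value for compound 2, the range is kept wide. Compound 4 is thus estimated at 70%, expected to fall between 56% and 82%.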

Compound 4, a percentage reported as activity, at one concentration (the size of the read-out at that concentration, not a potency): 27.9%
Beside the measured number, compound 4's estimate is 42.1 percentage points above it, outside the stated range (below it).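

In this assay the change from hydrogen to ethyl on an oxygen next to a carbonyl group gives a number 33.7 percentage points lower from compound 2 to compound 4 (beyond the scatter), a large step on the core of compound 2. Set beside the earlier step, the same change does not keep its direction from one core to the other: the same change on two cores in this assay, a number 13.7 percentage points higher (beyond the scatter) from compound 1 to compound 3 and a number 33.7 percentage points lower (beyond the scatter) from compound 2 to compound 4, 47.4 percentage points apart, beyond the scatter of two such steps

This shows that, at the one concentration tested, the read-out after carboxy to ethoxycarbonyl depends on the core carrying it, so the step on one core cannot serve as an estimate for the other; it does not show which feature of the cores is responsible, and two pairs give no rule for the wider series, nor any statement about potency.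

The compounds shown leave open how other groups on this carboxy position would read on the two cores, for example a methyl ester, an ester with a longer chain or an amide. Also open is which part of the difference between the core of compound 1 and the core of compound 2 goes with the reversal, as no pair shown splits that difference into single changes.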